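Moving a methyl group on the benzyl of compound 2

The compounds below may be only part of what the source reports. "The series", "measured", "known", "first", "only" and "open" are said of these compounds alone.

Of the compounds shown here, three have been measured in a functional assay on RAW264.7 cells (Mus musculus) for inhibition, read by Griess assay, with stated times of 2 h and 24 h; a lower number here means a stronger inhibitor, a higher number a weaker inhibitor. Going by the values given here, compound 1 `COc1ccc([C@@H]2C/C(=N\O)c3c(O)cc(OCc4cn(CC5CC5)nn4)cc3O2)cc1O` gives 6320 nM in this assay, and compound 3 `COc1ccc([C@@H]2C/C(=N\O)c3c(O)cc(OCc4cn(C5CCCC5)nn4)cc3O2)cc1O` gives 6880 nM; the one measured step between them, a 1.1-fold higher number from compound 1 to compound 3 (0.04 log units; within the scatter), stays within the scatter. Compound 2 `COc1ccc([C@@H]2CC(=O)c3c(O)cc(OCc4cn(Cc5ccc(C)cc5)nn4)cc3O2)cc1O` gives the highest of the three numbers, 16800 nM, and its gaps to compound 3 and to compound 1 both lie beyond the scatter. Compound 4 `COc1ccc([C@@H]2CC(=O)c3c(O)cc(OCc4cn(Cc5ccccc5C)nn4)cc3O2)cc1O` is not yet measured; it differs from compound 2 by 2-methylphenyl in place of 4-methylphenyl on a saturated chain carbon bound to an aromatic nitrogen. Among the compounds with values here, no measured step concerns this change, and the one measured step involves a different core and a different group, so no shift beyond the scatter is expected. For compound 4 the estimated value is 16800 nM, with a range from 8000 nM to 35000 nM. This corresponds to an expected step of no change at the digits printed from compound 2 to compound 4 (within the scatter).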

Compound 4, half-maximal inhibitory concentration: 13100 nM
Compound 4: the middle estimate sits 1.3-fold (0.11 log units) above what was measured; the range from low to high includes it.
By their numbers in this assay, from the lowest: compounds 1, 3, 4 and 2 (each within the scatter of the next, the first and the last beyond it).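

In this assay the swap of 4-methylbenzyl for 2-methylbenzyl gives a 1.3-fold lower number from compound 2 to compound 4 (0.11 log units; within the scatter) and so cannot be told apart from repeat measurement. Going by these compounds alone, this is the first step measured within the core of compound 2, and it shows that this particular relocation of the methyl group on the benzyl leaves the reading unresolved from that of compound 2. No available evidence bears on this result. Still open, on these data alone, is how this position responds to a benzyl carrying an amine or a carboxylic acid in place of the methyl group. As far as these compounds go, a longer chain between the phenyl ring and the aromatic nitrogen also remains open.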